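This account rests on a few compounds, and the source may have more. Where it says the series, first, only, none or still open, it means among the compounds named here.

In a functional assay on ACHN cells (Homo sapiens) for cytotoxicity, read by sulforhodamine B assay, with a stated time of 72 h (a lower number here means a stronger inhibitor of growth, a higher number a weaker inhibitor of growth), compound 1 (`O=C(Nc1ccc(C(F)(F)F)cc1)C1CCc2ccccc2N1`) gives 25000 nM and compound 3 (`O=C(Nc1ccccc1O)C1CCc2ccccc2N1C(=O)c1ccccc1`) gives 4260 nM on the same scale. Compound 2 (`CC(=O)N1c2ccccc2CCC1C(=O)Nc1cc(C(F)(F)F)cc(C(F)(F)F)c1`) gives > 70000 nM as a limit and not a number, which leaves it with no exact place on that scale (the limit of > 70000 nM in this assay, at which 1 of the 3 values shown sits).

Compound 4 (`O=C(Nc1cc(C(F)(F)F)cc(C(F)(F)F)c1)C1CCc2ccccc2N1`) has not been measured yet, and its structure departs from that of compound 2 in one place (hydrogen in place of acetyl on a nitrogen on an aromatic ring in a ring). In plain terms, hydrogen stands in place of acetyl on a nitrogen on an aromatic ring in a ring, next to the ring atom that bears a large group.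

For the measured compounds named here, no measured pair shows this exchange, so the size of the step can only be judged indirectly. Going by the values given here, compound 1, the one measured compound with hydrogen on that nitrogen, gives 25000 nM in this assay. On that basis a step towards stronger growth inhibition, beyond the usual scatter, is expected, though a modest one. The estimated size is an at least 3.5-fold lower number from compound 2 to compound 4 (0.54 log units; beyond the scatter) as a working expectation. Compound 4 is expected to give about 20000 nM (estimated range 7000 nM to 60000 nM).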

Compound 4, concentration for 50% growth inhibition: 8190 nM
For compound 4 the middle estimate is 2.4-fold (0.39 log units) above the measured one, and the stated range covers the measured number.
By their numbers in this assay, from the lowest: compounds 3 and 4 (each within the scatter of the next); then compound 1. At a limit, above all of these: compound 2.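

In this assay, for the compounds shown here, the exchange of acetyl for hydrogen on this ring nitrogen can now be read directly for the first time, with the rest of the structure held the same, and it shows an at least 8.5-fold lower number from compound 2 to compound 4 (0.93 log units; beyond the scatter) in growth inhibition terms. Compound 2 stands at > 70000 nM as a limit of the assay and not a number. The step therefore has a lower bound but no known upper end, because compound 2 has no exact place on the scale: the limit of > 70000 nM in this assay, at which 1 of the 4 values shown sits.

The compounds shown leave open whether the acetyl group is unusual in this position or whether any group on this nitrogen would go with the same loss of growth inhibition, since only hydrogen and acetyl can be compared here on an otherwise unchanged structure. A small methyl group or a longer chain ending in an amine on that nitrogen would show whether the result depends on the carbonyl of the acetyl or simply on having hydrogen there, and compound 3 cannot settle this as it differs in more than one place.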